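A shorter, unsaturated link from ring to nitrogen

The source may report more compounds than this note shows. Statements on the series, on what has been measured and on what is new or still open speak of the compounds shown alone.

Three compounds share a piperidine-based core with an arene tethered to the ring nitrogen. Compound 1 `COc1ccc(CCCN2CCC(CNC(c3ccccc3)c3ccccc3)CC2)cc1` gives 2800 nM in a functional assay on cells (T-cell line, Homo sapiens) for inhibition; a higher number here means a weaker inhibitor, a lower number a stronger inhibitor. Compound 2 `COc1ccc(CCCN2CCC(COCc3ccccc3)CC2)cc1` gives 2100 nM in this assay. Compound 3 `Cc1ccc(CCCN2CCC(COC(c3ccccc3)c3ccccc3)CC2)cc1` gives 200 nM in this assay, the lowest of the three numbers; its gap to compound 2 and its gap to compound 1 both lie beyond the usual scatter, so compound 3 is the strongest inhibitor among the measured compounds.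

The unmeasured compound 4 `C(#Cc1ccccc1)CN1CCC(COC(c2ccccc2)c2ccccc2)CC1` keeps the core of compound 3 and changes only the tether to the arene: 2-phenylethynyl in place of 2-(4-methylphenyl)ethyl on a saturated chain carbon bound to an amine nitrogen in a ring. Seen one bond further out, this is 3-(4-methylphenyl)propyl becoming 3-phenylprop-2-yn-1-yl. Among the measured compounds shown here, no measured pair shows this kind of change, so no step of known size can guide the expectation. Two things happen at once here, the loss of the methyl on the arene and the arrival of a triple bond in the chain, and neither can be weighed from the measured compounds. A modest weakening is expected, on the order of a 3.0-fold higher number from compound 3 to compound 4 (0.48 log units; beyond the scatter), within the wide margin this uncertainty demands. Compound 4 is therefore estimated at 600 nM, with a likely range from 150 nM to 2500 nM.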

Compound 4, half-maximal inhibitory concentration: > 20000 nM
Compound 4: a limit, no number; the forecaster's own chance of this, stated with the estimate: 3%; middle value at least 33-fold (1.52 log units) from the limit.
By their numbers in this assay, from the lowest: compound 3; then compounds 2 and 1 (each within the scatter of the next). At a limit, above all of these: compound 4.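

Compound 4 carries a limit of the assay, not a number: the limit of > 20000 nM in this assay, at which 1 of the 4 values shown sits. Replacing 3-(4-methylphenyl)propyl with 3-phenylprop-2-yn-1-yl on the carbon chain attached to the ring nitrogen gives an at least 100-fold higher number from compound 3 to compound 4 (2.00 log units; beyond the scatter), so a change confined to this tether, with the rest of the core left intact, can all but remove measurable inhibition in this assay. The earlier compounds shown here could not show this, as all three carry a saturated chain at this place and differ from one another elsewhere, so the tether's sensitivity to change only comes into view with compound 4.

Two things changed together, the loss of the methyl on the arene and the arrival of a triple bond in the chain, and the compounds shown cannot say how much of the loss belongs to each. A plain 3-phenylpropyl tether would test the methyl alone and a 3-(4-methylphenyl)prop-2-yn-1-yl tether the triple bond alone, while a double bond in the chain would ask whether any unsaturation at this place is enough to weaken inhibition.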